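Aryl urea series: trifluoromethyl in place of fluoro

This account rests on a few compounds, and the source may have more. Where it says the series, first, only, none or still open, it means among the compounds named here.

Three ureas are measured. Compound 2 `C[C@@H](NC(=O)Nc1ccccc1F)c1ccccc1` gives 95% in an ADME assay on the whole organism with Oryza sativa as the target, tested at 1 uM; a higher number here means a weaker effect of the compound at the concentration tested, a lower number a stronger effect. Compound 1 `C[C@@H](NC(=O)Nc1ccccc1C(F)(F)F)c1ccccc1` gives 95% in this assay; no change at the digits printed from compound 2 to compound 1 (within the scatter), the change being (trifluoromethyl in place of fluoro on an aromatic carbon). Compound 3 `C[C@@H](NC(=O)Nc1cccc(F)c1F)c1ccccc1` gives 99% in this assay; a number 4 percentage points higher from compound 2 to compound 3 (within the scatter), the change being fluoro in place of hydrogen on an aromatic carbon. All three numbers lie within the usual scatter of one another, so no order among them is read.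

Compound 4 `C[C@@H](NC(=O)Nc1cccc(C(F)(F)F)c1F)c1ccccc1` is not yet measured. It differs from compound 3 by trifluoromethyl in place of fluoro on an aromatic carbon. This is the same kind of change as that from compound 2 to compound 1, not the same: in compound 4 the entering group sits ortho to a fluoro group and meta to a large group, whereas in compound 1 it sits ortho to a large group. The two cores differ by fluoro in place of hydrogen on an aromatic carbon.

A small step is expected for compound 4, a number 2 percentage points lower from compound 3 to compound 4 (within the scatter), because the earlier step of no change at the digits printed from compound 2 to compound 1 (within the scatter) stayed within the scatter. Compound 4 is estimated at 97%, expected between 88% and 100%.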

Compound 4, a percentage reported as activity, at one concentration (the size of the read-out at that concentration, not a potency): 99%
The estimate for compound 4 lay 2 percentage points below the measured number; the range from low to high includes it.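

In this assay, trifluoromethyl in place of fluoro on the aromatic carbon ortho to a fluoro group gives no change at the digits printed from compound 3 to compound 4 (within the scatter), while the step from the unsubstituted position gives a number 4 percentage points higher from compound 2 to compound 4 (within the scatter). Set beside the earlier step, the same change reads alike on both cores: the same change on two cores in this assay, no change at the digits printed (within the scatter) from compound 2 to compound 1 and no change at the digits printed (within the scatter) from compound 3 to compound 4, 0 percentage points apart, within the scatter of two such steps. Within the data shown here, this shows only that the change carries across these two cores without a step beyond the scatter; since neither step registers any effect, it does not show that a real effect of the change is conserved, nor does it predict the outcome on another core or at another concentration.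

The compounds shown carry only fluoro and trifluoromethyl on the aromatic ring, so it remains open whether any substituent there can give a step beyond the scatter in this assay. An amine or a carboxylic acid on that ring, or a longer chain in place of the methyl on the shared core, would test this.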